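A fluoro step from compound 2 to compound 4

A few compounds are considered here, and "the series" means these few. Any claim that something is new, unique, unknown or untested is made for them only; others in the source may bear on it.

In an ADME assay on Vero cells (Chlorocebus sabaeus) for cytotoxicity, read by MTT assay, with a stated time of 72 h (on this read-out lower numbers stand for higher toxicity in this test and higher numbers for lower toxicity in this test), compound 2 (`COC(=O)c1cc(-c2cccc(NC(=O)c3ccc(/C=C/C(=O)c4ccccc4)cc3)c2)on1`) gives > 50 ug/mL as its reading, and that is a limit, not a number. Compound 1 (`COC(=O)c1cc(-c2cccc(NC(=O)c3ccc(OCc4ccc(Cl)cc4)cc3)c2)on1`) gives > 80 ug/mL as a limit too. Compound 3 (`COC(=O)c1cc(-c2cccc(NC(=O)c3ccc(/C=C/C(=O)c4cc(OC)c(OC)c(OC)c4)cc3)c2)on1`) gives > 50 ug/mL as a limit as well. Compound 2 therefore has no exact position on this scale.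

Compound 4 (`COC(=O)c1cc(-c2cccc(NC(=O)c3ccc(/C=C/C(=O)c4ccc(F)cc4)cc3)c2)on1`) has fluoro in place of hydrogen on an aromatic carbon of compound 2, with phenyl becoming 4-fluorophenyl (fluoro in place of hydrogen on an aromatic carbon). Among the compounds with values here, two measured steps bear on this change. The closer in kind is a step that the two limits leave unreadable from compound 2 to compound 3 with 3,4,5-trimethoxyphenyl in place of phenyl on a carbonyl carbon. The other is a step that the two limits leave unreadable from compound 1 to compound 2 with 2-benzoylethenyl in place of (4-chlorobenzyl)oxy on an aromatic carbon. Neither has a readable size, so neither gives a measure for the fluoro change.

Compound 3 replaces the same phenyl and its > 50 ug/mL remains a limit, so no step beyond the scatter is expected in this assay and no direction can be given. The estimated step that the limit leaves unreadable from compound 2 to compound 4 is accordingly expected to be small. Compound 4 is expected at 60 ug/mL with an estimated range from 30 ug/mL to 120 ug/mL.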

Compound 4, half-maximal cytotoxic concentration: > 20 ug/mL
Compound 4: no number, only a limit; the forecaster's own chance of this, stated with the estimate: 75%; the middle value is on the limit's open side.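

In this assay compound 4 gives > 20 ug/mL, a limit and not a number. Within the data shown here, compound 1, compound 2 and compound 3 also carry only limits, and no step from any of them to compound 4 can be read. The compounds shown leave open whether fluoro in place of hydrogen shifts this reading at all, and in which direction.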